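Replacing an amide with a urea bearing a carboxylic acid

The compounds below may be only part of what the source reports. "The series", "measured", "known", "first", "only" and "open" are said of these compounds alone.

Compound 1 `CC(=O)N1CC[C@H](C(=O)N2CC[C@](c3ccc(C(OCc4c(F)cccc4F)(C(F)(F)F)C(F)(F)F)cc3)(S(=O)(=O)c3ccc(F)cc3)C2)C1` sits in the middle of three compounds in an ADME assay on microsomes from liver (Mus musculus) for metabolic stability, with a stated time of 10 min (on this read-out higher numbers stand for a more stable compound and lower numbers for a less stable compound), where compound 1 gives 57%. Compound 2 `CC(=O)N1CCC(O)(C(=O)N2CC[C@](c3ccc(C(OCc4c(F)cccc4F)(C(F)(F)F)C(F)(F)F)cc3)(S(=O)(=O)c3ccc(F)cc3)C2)CC1` reaches 69%, a rise of a number 12 percentage points higher from compound 1 to compound 2 (beyond the scatter). Compound 3 `O=C(N1CCOCC1)N1CC[C@](c2ccc(C(OCc3c(F)cccc3F)(C(F)(F)F)C(F)(F)F)cc2)(S(=O)(=O)c2ccc(F)cc2)C1` gives only 18%, a drop of a number 39 percentage points lower from compound 1 to compound 3 (beyond the scatter); from compound 2 to compound 3 the fall is a number 51 percentage points lower from compound 2 to compound 3 (beyond the scatter).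

Compound 4 `O=C(O)C1CCN(C(=O)N2CC[C@](c3ccc(C(OCc4c(F)cccc4F)(C(F)(F)F)C(F)(F)F)cc3)(S(=O)(=O)c3ccc(F)cc3)C2)CC1` changes compound 1 by 4-carboxypiperidin-1-yl in place of 1-acetylpyrrolidin-3-yl on a carbonyl carbon. The closest guide is the step to compound 3, which also swaps the 1-acetylpyrrolidin-3-yl for a ring nitrogen on the carbonyl carbon and fell sharply in this assay. Compound 4, however, carries a 4-carboxypiperidin-1-yl with a hydrogen-bond donor instead of morpholin-4-yl, so a fall of the same size is not certain. A moderate decrease in this assay is therefore expected, with wide uncertainty.

Compound 4 is estimated to give 42%, within 18% to 70%, meaning an expected step of a number 15 percentage points lower from compound 1 to compound 4 (beyond the scatter).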

Compound 4, percent of the compound remaining: 84%
For compound 4 the middle estimate is 42 percentage points below the measured one; measured number above the stated range.
By their numbers in this assay, from the lowest: compound 3; then compound 1; then compound 2; then compound 4.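

Attaching the ring through its nitrogen on this carbonyl carbon does not in itself go with a low number in this assay, since 4-carboxypiperidin-1-yl in place of morpholin-4-yl gives a number 66 percentage points higher from compound 3 to compound 4 (beyond the scatter) on the same urea link. The new group also outperforms both groups joined through a ring carbon, with a number 27 percentage points higher from compound 1 to compound 4 (beyond the scatter) and a number 15 percentage points higher from compound 2 to compound 4 (beyond the scatter), which makes compound 4 the most stable of the four on this read-out. No measurement at hand explains why these groups differ so widely.

As far as these compounds go, the step from compound 3 to compound 4 changes the ring and adds the carboxylic acid at once, so the share of each remains open. A plain piperidin-1-yl, a methyl ester of the acid or a 3-carboxypiperidin-1-yl would help to separate these contributions.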